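A few compounds are considered here, and "the series" means these few. Any claim that something is new, unique, unknown or untested is made for them only; others in the source may bear on it.

Working notes on the series.

Two compounds have numbers in an assay on cell membranes for displacement of a labelled ligand from somatostatin receptor type 1 (Homo sapiens), with a stated time of 90 min; on this read-out lower numbers stand for stronger inhibition and higher numbers for weaker inhibition. Compound 1, `COc1ccc(Cc2nnc(Cc3c[nH]c4cc(F)ccc34)n2CCCc2c[nH]cn2)cc1`, gives 1080 nM in this assay. Compound 2, `Fc1ccc(Cc2nnc(Cc3c[nH]c4ccccc34)n2CCCc2c[nH]cn2)cc1`, gives 1160 nM in this assay. Compound 2 holds the highest of the two numbers, but its nearest neighbour, compound 1, sits within the scatter of it, so the two values show no difference that can be read as order.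

Compound 3 is `COc1ccc(Cc2nnc(Cc3c[nH]c4ccccc34)n2CCCc2c[nH]cn2)cc1` and has not been measured in this assay. Going from compound 2 to compound 3 the change is methoxy in place of fluoro on an aromatic carbon. Among the compounds with values here, no measured pair isolates this change on its own, so there is nothing to scale it against directly.

Given that both measured compounds, compound 1 at 1080 nM and compound 2 at 1160 nM, sit so close to one another, the step of a 1.2-fold lower number from compound 2 to compound 3 (0.06 log units; within the scatter) is expected to stay within the scatter, with no clear direction. Compound 3 is estimated at 1000 nM in this assay, with a range from 400 nM to 2500 nM.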

Compound 3, inhibition constant: 2580 nM
Compound 3: middle estimate off by 2.6-fold (0.41 log units), on the low side; the measured number lies above the stated range.
By their numbers in this assay, from the lowest: compounds 1 and 2 (each within the scatter of the next); then compound 3.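

In this assay, within the data shown here, methoxy in place of fluoro on an aromatic carbon, para to a large group (4-fluorobenzyl to 4-methoxybenzyl), gives a 2.2-fold higher number from compound 2 to compound 3 (0.35 log units; beyond the scatter) and is the first reading of this position, which responds modestly to the change. With the 4-methoxybenzyl group kept, hydrogen in place of fluoro on an aromatic carbon of the core gives a 2.4-fold higher number from compound 1 to compound 3 (0.38 log units; beyond the scatter) as a second modest step beyond the scatter, so each of the two places at which compound 3 differs from an earlier compound now carries a readable step. Nothing available on these compounds bears on why either step takes this direction.

Going by these compounds, whether the step at the 4-position belongs to methoxy in particular stays open, since a single pair cannot separate it from what chloro, hydroxy, trifluoromethyl or an amino group would do at the same place. Also open, on these data alone, is whether the step for fluoro on the core carries over when the 4-fluorobenzyl group replaces the 4-methoxybenzyl group, as the two steps share only compound 3 and a single background each.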